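Removing the acetyl group from compound 3

This account rests on a few compounds, and the source may have more. Where it says the series, first, only, none or still open, it means among the compounds named here.

In a functional assay on HT-29 cells (Homo sapiens) for inhibition (on this read-out lower numbers stand for stronger inhibition and higher numbers for weaker inhibition), compound 1 `COc1ccc(/C=C/c2ccc3ccccc3c2)cc1` gives > 5000 nM as a limit of the assay and not as a number. Compound 2 `FC(F)(F)c1ccc(/C=C/c2ccc3ccccc3c2)cc1` gives > 5000 nM as a limit too. Among the compounds with values here, compound 3 `COc1cc(/C=C\c2cn(C(C)=O)c3ccccc23)cc(OC)c1OC` gives 2850 nM as the only actual number among the three. The change hydrogen in place of acetyl on an aromatic nitrogen turns compound 3 into compound 4 `COc1cc(/C=C\c2c[nH]c3ccccc23)cc(OC)c1OC` with hydrogen in place of acetyl on an aromatic nitrogen. Within the data shown here, the only measured step, a step that the two limits leave unreadable from compound 1 to compound 2 for trifluoromethyl in place of methoxy on an aromatic carbon, offers little guidance. Both of its ends sit at the limit of > 5000 nM in this assay, at which 2 of the 3 values shown sit, and so it has no size to carry over. It also concerns a different group on the core of compound 1. The expectation therefore rests on compound 3 at 2850 nM and on the change itself. The expected shift is a 2.4-fold lower number from compound 3 to compound 4 (0.38 log units; beyond the scatter) towards stronger inhibition in this assay and it is held only loosely. Compound 4 is estimated at 1200 nM with an estimated range between 150 nM and 6000 nM as its ends.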

Compound 4, half-maximal inhibitory concentration: 3230 nM
Compound 4: middle estimate off by 2.7-fold (0.43 log units), on the low side; measured number inside the range.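

In this assay, hydrogen in place of acetyl on the aromatic nitrogen gives a 1.1-fold higher number from compound 3 to compound 4 (0.05 log units; within the scatter), so the step has no readable size. Within the data shown here, no earlier step touched this position, and this first reading shows that the acetyl and the hydrogen on that nitrogen cannot be told apart on this read-out, at least on the shared core of compound 3 and compound 4. Compound 1 and compound 2 each stand as a limit and not as a number, so neither offers a size to set beside this step: the limit of > 5000 nM in this assay, at which 2 of the 4 values shown sit.

The compounds shown leave open whether any other group on this nitrogen, such as a methyl, a longer chain or a carboxylic acid, would move the number beyond the scatter. They also leave open whether hydrogen and acetyl would remain indistinguishable on a different core.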